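The source may hold more compounds than are shown below. What is called first, only, known or untested is meant among the compounds shown, and "the series" means these compounds.

Compound 1 `C#Cc1cccc(-n2ccc3cc(OC)cc(OC)c3c2=O)c1` gives 25200 nM in a functional assay on A549 cells (Homo sapiens) for antiproliferative activity, read by MTT assay, with a stated time of 72 h; a lower number here means a stronger inhibitor, a higher number a weaker inhibitor.
Compound 2 `C#Cc1cccc(-n2ccc3cc(OC)cc(O)c3c2=O)c1` gives 15900 nM.
Compound 3 `C=CC(=O)Nc1c(OC)cc(OC)c2c(=O)n(-c3cccc(C(=O)N4CCCCC4)c3)ccc12` gives 14700 nM.

Compound 1 and compound 2 differ in one place: hydrogen in place of methyl on an oxygen on an aromatic ring. That change produced a 1.6-fold lower number from compound 1 to compound 2 (0.20 log units; within the scatter). Compound 4 `C=CC(=O)Nc1c(OC)cc(O)c2c(=O)n(-c3cccc(C(=O)N4CCCCC4)c3)ccc12` is not yet measured; it carries the same change relative to compound 3: hydrogen in place of methyl on an oxygen on an aromatic ring. The difference between the core of compound 1 and the core of compound 3 is not broken down here. Among the measured compounds shown here, for compound 4 a step of similar small size is expected, a 1.5-fold lower number from compound 3 to compound 4 (0.19 log units; within the scatter), which rests on the one measured instance of this change, the step between compound 1 and compound 2 of a 1.6-fold lower number from compound 1 to compound 2 (0.20 log units; within the scatter). Compound 4 is therefore estimated at 9500 nM, with the likely range running from 4000 nM to 24000 nM.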

Compound 4, half-maximal inhibitory concentration: 14700 nM
Beside the measured number, compound 4's estimate is 1.5-fold (0.19 log units) below it; low and high end bracket the measured number.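

In this assay, replacing methoxy with hydroxy gave no change at the digits printed from compound 3 to compound 4 (within the scatter). Set beside the earlier step, the same change looks alike on the two cores: the same change on two cores in this assay, a 1.6-fold lower number (0.20 log units; within the scatter) from compound 1 to compound 2 and no change at the digits printed (within the scatter) from compound 3 to compound 4, 1.6-fold (0.20 log units) apart, within the scatter of two such steps. This shows that, on both cores, the change left the number within the scatter, but it does not show that the same would hold on a third core, and two pairs cannot reveal a small real effect hidden in that scatter.

The compounds shown leave open whether an ethyl group or a longer chain on that oxygen, or an amine in place of the oxygen, would move the number beyond the scatter. Also open, on these data alone, is whether this step would look the same in another cell line.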